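A second iodo group on compound 2

A few compounds are considered here, and "the series" means these few. Any claim that something is new, unique, unknown or untested is made for them only; others in the source may bear on it.

Measured so far in an ADME assay on L6 cells (Rattus norvegicus) for cytotoxicity, read by resazurin assay, with a stated time of 72 h; a lower number here means a stronger inhibitor, a higher number a weaker inhibitor:
compound 1 `N=C(N)c1cc(I)c(OCc2cccc([N+](=O)[O-])c2)c(I)c1` gives 7720000 nM
compound 2 `N=C(N)c1cccc(COc2ccc(C(=N)N)cc2I)c1` gives 6060000 nM
compound 3 `COc1cc(C(=N)N)ccc1OCc1cccc(C(=N)N)c1` gives 85400000 nM

Compound 2 stands at the low end of these three numbers, level within the scatter with compound 1. Compound 4 `N=C(N)c1cccc(COc2c(I)cc(C(=N)N)cc2I)c1` differs from compound 2 in one place, iodo in place of hydrogen on an aromatic carbon is the whole change. The closest measured step is a 14-fold higher number from compound 2 to compound 3 (1.15 log units; beyond the scatter) with methoxy in place of iodo, a large rise. Compound 1 also carries two iodo groups but differs elsewhere, and its 7720000 nM gives little further guidance. Only a small step towards a lower number is therefore expected in this assay, namely a 1.7-fold lower number from compound 2 to compound 4 (0.24 log units; within the scatter) as estimated here. For compound 4 the estimate is 3500000 nM within a range of 1200000 nM to 10000000 nM as expected limits.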

Compound 4, half-maximal inhibitory concentration: 19300000 nM
The estimate for compound 4 lay 5.5-fold (0.74 log units) below the measured number; measured number outside the range, above it.
By their numbers in this assay, from the lowest: compounds 2 and 1 (each within the scatter of the next); then compound 4; then compound 3.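

In this assay, iodo in place of hydrogen on this aromatic carbon gives a 3.2-fold higher number from compound 2 to compound 4 (0.50 log units; beyond the scatter), so a second iodo group here raises the number rather than lowering it. With both iodo groups present, a group of 3 heavy atoms (1 carbon, 2 nitrogen; no ring) in place of a group of 3 heavy atoms (1 nitrogen, 2 oxygen; no ring) gives a 2.5-fold higher number from compound 1 to compound 4 (0.40 log units; beyond the scatter), a further modest step. Nothing available bears on the reason for either rise. Going by these compounds, how chloro, an amine or a carboxylic acid at this position would compare remains open.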